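This account rests on a few compounds, and the source may have more. Where it says the series, first, only, none or still open, it means among the compounds named here.

Compound 1 `COc1cc2c(c(OCc3ccccc3)c1OC)C(=O)[C@]1(OC)C=C[C@H]2N(C(=O)OCC(C)C)N1C(=O)OCC(C)C`: 94 ug/mL
Compound 2 `COC(=O)N1[C@@H]2C=C[C@@](OC)(C(=O)c3c2cc(OC)c(OC)c3OCc2ccc(F)cc2)N1C(=O)OC`: 56.6 ug/mL

Both values come from an ADME assay on KB cells (Homo sapiens) for cytotoxicity; a lower number here means that less compound is needed, a higher number that more compound is needed for the effect. Compound 1 gives 94 ug/mL and compound 2 gives 56.6 ug/mL, and these two numbers lie within the usual scatter of each other. For the measured compounds named here, compound 1 therefore stands level with the only other measured compound.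

Compound 3 `COc1cc2c(c(OCc3ccccc3F)c1OC)C(=O)[C@]1(OC)C=C[C@H]2N(C(=O)OCC(C)C)N1C(=O)OCC(C)C` departs from compound 1 at one place, fluoro in place of hydrogen on an aromatic carbon, ortho to a large group, so that benzyloxy becomes (2-fluorobenzyl)oxy.

Going by the values given here, no pair of measured compounds differs at one place only, so the series offers no direct precedent for this change. The expected 1.1-fold lower number from compound 1 to compound 3 (0.04 log units; within the scatter) is none beyond the scatter, with no direction favoured in this assay. For compound 3 the estimated value is 85 ug/mL, with an expected range of 45 ug/mL to 160 ug/mL.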

Compound 3, concentration for half-maximal effect: 109 ug/mL
Compound 3: the middle estimate sits 1.3-fold (0.11 log units) below what was measured, and the stated range covers the measured number.
By their numbers in this assay, from the lowest: compounds 2, 1 and 3 (each within the scatter of the next).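

In this assay, for the compounds shown here, the step from benzyloxy to (2-fluorobenzyl)oxy reads as a 1.2-fold higher number from compound 1 to compound 3 (0.06 log units; within the scatter) and is the first single-place step. It shows that fluoro on this aromatic carbon, ortho to a large group, leaves the number within the scatter, so this position accepts this one small change with no readable effect. No measured property of the compounds accompanies this step, and nothing in the data speaks to what lies behind the result.

Compound 2 also carries a fluoro on its benzyl group but differs from compound 1 in more than one place, so it says nothing about this step alone. Still open, going by these compounds, is whether a different group on the same carbon, such as chloro, methoxy or an amine, would give a step beyond the scatter, and whether a carboxylic acid there would do the same.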